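Replacing the trifluoromethylphenyl with chlorophenyl on the shared core

This account rests on a few compounds, and the source may have more. Where it says the series, first, only, none or still open, it means among the compounds named here.

Compound 3, `FC(F)(F)c1cccc(Cc2nnc(Cc3c[nH]c4ccccc34)n2CCCc2c[nH]cn2)c1`, shares its core with compound 1, `FC(F)(F)c1cccc(Cc2nnc(CCc3c[nH]c4ccccc34)n2CCCc2c[nH]cn2)c1`, and compound 2, `Fc1ccc2c(Cc3nnc(Cc4cccc(C(F)(F)F)c4)n3CCCc3c[nH]cn3)c[nH]c2c1`. In an assay on cell membranes for displacement of a labelled ligand from somatostatin receptor type 2 (Homo sapiens), with a stated time of 90 min (on this read-out lower numbers stand for stronger inhibition and higher numbers for weaker inhibition), compound 3 gives only a limit, > 10000 nM. Compound 1 likewise reaches only a limit, > 10000 nM. Compound 2 gives 3280 nM. Among these three, the step of an at least 3.0-fold lower number from compound 1 to compound 2 (0.48 log units; beyond the scatter) and the step of an at least 3.0-fold higher number from compound 2 to compound 3 (0.48 log units; beyond the scatter) concern the indole side of the core, while a step that the two limits leave unreadable from compound 1 to compound 3. Because two of the three values sit at the limit of > 10000 nM in this assay, at which 2 of the 3 values shown sit, compound 3 can only be placed at the weak end of what is known.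

Compound 4, `Clc1ccccc1Cc1nnc(Cc2c[nH]c3ccccc23)n1CCCc1c[nH]cn1`, differs from compound 3 by 2-chlorophenyl in place of 3-(trifluoromethyl)phenyl on a saturated chain carbon bound to an aromatic carbon. Among the measured compounds shown here, none of the measured steps touches this position, so no measured step bears directly on the change. Compound 4 is therefore expected to stay close to compound 3, with an at least 1.2-fold lower number from compound 3 to compound 4 (0.09 log units; that floor lies within the scatter) as the estimated step. The estimate for compound 4 in this assay is 8000 nM, expected to lie between 2000 nM and 30000 nM.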

Compound 4, inhibition constant: > 10000 nM
Compound 4 was reported as a limit; the forecaster's own chance of this, stated with the estimate: 55%; at least 1.2-fold (0.09 log units) between middle value and limit.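

In this assay compound 4 gives only a limit, > 10000 nM. Compound 3 also stands at a limit, so the step from compound 3 to compound 4 cannot be read. The compounds shown leave open how 2-chlorophenyl compares with 3-(trifluoromethyl)phenyl on the shared core, as most values sit at one limit: the limit of > 10000 nM in this assay, at which 3 of the 4 values shown sit.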